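The source may hold more compounds than are shown below. What is called first, only, known or untested is meant among the compounds shown, and "the series" means these compounds.

Measured compounds:
Compound 1, `COc1ncnc2c1c(-c1ccsc1)cn2[C@@H]1O[C@H](CO)[C@@H](O)[C@H]1O`: 130 nM
Compound 2, `CNc1ncnc2c1c(-c1ccsc1)cn2[C@@H]1O[C@H](CO)[C@@H](O)[C@H]1O`: a limit of the assay, > 20000 nM
Compound 3, `COc1ncnc2c1c(-c1cc3ccccc3o1)cn2[C@@H]1O[C@H](CO)[C@@H](O)[C@H]1O`: 4470 nM

All three were tested in a functional assay on HL-60 cells (Homo sapiens) for antiproliferative activity, read by XTT assay, with a stated time of 72 h; a higher number here means a weaker inhibitor, a lower number a stronger inhibitor. Compound 1 is the starting point of both measured steps. Replacing methoxy with methylamino, (methylamino in place of methoxy on an aromatic carbon), gave an at least 150-fold higher number from compound 1 to compound 2 (2.18 log units; beyond the scatter). For compound 2 the assay returned only a limit, and its size is described by the limit of > 20000 nM in this assay, at which 1 of the 3 values shown sits; the true step may be larger than the limit shows. Replacing thiophen-3-yl with 1-benzofuran-2-yl, (1-benzofuran-2-yl in place of thiophen-3-yl on an aromatic carbon), gave a 34-fold higher number from compound 1 to compound 3 (1.54 log units; beyond the scatter).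

Compound 4, `CNc1ncnc2c1c(-c1cc3ccccc3o1)cn2[C@@H]1O[C@H](CO)[C@@H](O)[C@H]1O`, has not been measured. It differs from compound 3 by methylamino in place of methoxy on an aromatic carbon, the same change that turned compound 1 into compound 2, made on the same place of the shared core. The two cores differ by 1-benzofuran-2-yl in place of thiophen-3-yl on an aromatic carbon.

Compound 4 is expected to come out at 60000 nM, within a range from 15000 nM to 400000 nM. The step this estimate means is expected to be a 13-fold higher number from compound 3 to compound 4 (1.13 log units; beyond the scatter). This expectation rests on compound 1 and compound 2, whose step an at least 150-fold higher number from compound 1 to compound 2 (2.18 log units; beyond the scatter) was large, and on compound 3 already standing at 4470 nM. If the same change weakens compound 3 to a like degree, compound 4 would most likely fall beyond what the assay can report as a number, so a limit rather than a value is the likeliest outcome.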

Compound 4, half-maximal inhibitory concentration: 8950 nM
Compound 4: middle estimate off by 6.7-fold (0.83 log units), on the high side; measured number outside the range, below it.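

In this assay, the change of methoxy to methylamino did not carry over from one core to the other: on the core bearing 1-benzofuran-2-yl it gave a 2.0-fold higher number from compound 3 to compound 4 (0.30 log units; within the scatter), and set beside the step on the core bearing thiophen-3-yl, the two clearly differ: the same change on two cores in this assay, an at least 150-fold higher number (2.18 log units; beyond the scatter) from compound 1 to compound 2 and a 2.0-fold higher number (0.30 log units; within the scatter) from compound 3 to compound 4, at least 76-fold (1.88 log units) apart, beyond the scatter of two such steps

The swap of thiophen-3-yl for 1-benzofuran-2-yl also depends on the group it is paired with, since with methylamino in place it gave an at least 2.2-fold lower number from compound 2 to compound 4 (0.34 log units; beyond the scatter), and this runs opposite to the step seen with methoxy in place: the same change on two cores in this assay, a 34-fold higher number (1.54 log units; beyond the scatter) from compound 1 to compound 3 and an at least 2.2-fold lower number (0.34 log units; beyond the scatter) from compound 2 to compound 4, at least 76-fold (1.88 log units) apart, beyond the scatter of two such steps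

The value of compound 2, > 20000 nM, is a limit, so each gap is known only as a minimum, and these four compounds show that the two changes do not act independently, but not why, nor how the methylamino change would behave on a third core.

Left open is how far the result belongs to these particular groups: a plain amino group, a dimethylamino group or an ethoxy group in the same place on each core would test this. A phenyl or furan-2-yl group in place of the thiophen-3-yl or 1-benzofuran-2-yl group would show whether the same dependence holds on other cores.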